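A Third Methoxy Added to Compound 3

This account rests on a few compounds, and the source may have more. Where it says the series, first, only, none or still open, it means among the compounds named here.

Of the compounds shown here, three sharing one core have been measured in an assay on brain for displacement of a labelled ligand from Sigma non-opioid intracellular receptor 1 (Rattus norvegicus); on this read-out lower numbers stand for stronger inhibition and higher numbers for weaker inhibition. Compound 1 `Fc1cccc(CCCN[C@H]2C3C4CC5C6C4CC3C6C52)c1` gives 24.9 nM. Compound 2 `COc1cc(CN[C@H]2C3C4CC5C6C4CC3C6C52)cc(OC)c1OC` gives 1010 nM. Compound 3 `COc1ccc(CN(C)[C@H]2C3C4CC5C6C4CC3C6C52)cc1OC` gives 255 nM. Among these three numbers compound 3 stands second highest: its nearest neighbour is compound 2, whose number is higher by a margin beyond the scatter, and its furthest is compound 1, whose number is lower by a margin well beyond the scatter.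

Compound 4 `COc1cc(CN(C)[C@H]2C3C4CC5C6C4CC3C6C52)cc(OC)c1OC` is the next compound, not yet measured in this assay. It differs from compound 3 in one place: methoxy in place of hydrogen on an aromatic carbon, on an aromatic carbon of a six-membered aromatic ring of carbon only, ortho to a methoxy group, meta to a large group and meta to a methoxy group.

Among the measured compounds shown here, no directly comparable single step has been measured, so the size of this step is open. Compound 2, which also carries three methoxy groups on that ring, gives 1010 nM, a weaker number than compound 3, but compound 2 differs from compound 3 in two places, so this is only a hint. The step from compound 3 to compound 4 is expected to be a modest weakening, a 2.0-fold higher number from compound 3 to compound 4 (0.29 log units; within the scatter). Compound 4 is therefore estimated at 500 nM, with a range from 150 nM to 1700 nM.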

Compound 4, inhibition constant: 1220 nM
Compound 4: the middle estimate sits 2.4-fold (0.39 log units) below what was measured, and the stated range covers the measured number.
By their numbers in this assay, from the lowest: compound 1; then compound 3; then compounds 2 and 4 (each within the scatter of the next).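

In this assay, among the compounds shown here, methoxy in place of hydrogen on an aromatic carbon, ortho to a methoxy group, gives a 4.8-fold higher number from compound 3 to compound 4 (0.68 log units; beyond the scatter) as a change in one place, so a third methoxy group on this ring weakens the number by a margin the earlier compounds could only hint at. Methyl in place of hydrogen on an amine nitrogen gives a 1.2-fold higher number from compound 2 to compound 4 (0.08 log units; within the scatter) on the same read-out, so among compounds with three methoxy groups on the ring, that methyl makes no difference beyond the scatter, and the gap separating compound 3 from compound 2 goes with the added methoxy rather than with the methyl. Nothing available here bears on why the added methoxy has this effect.

Going by these compounds, whether the weakening belongs to methoxy itself or would also appear with a smaller substituent, such as a fluorine or a hydroxyl group, at this position remains open. For the compounds shown here, it is also open whether a methyl on the amine nitrogen would make as little difference with a longer chain between ring and nitrogen, as in compound 1, or with only two methoxy groups on the ring, as in compound 3.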